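Dihydropyridine series, aryl change on the bicyclic core

A few compounds are considered here, and "the series" means these few. Any claim that something is new, unique, unknown or untested is made for them only; others in the source may bear on it.

Measured so far:
compound 1 `CCOC(=O)C1=C(C)NC(C)=C(C(=O)OCC)C1c1c(-c2ccc(OC(F)(F)F)cc2)nc2sc(Br)cn12`: 93 nM
compound 2 `CCOC(=O)C1=C(C)NC(C)=C(C(=O)OCC)C1c1c(-c2ccccc2F)nc2sccn12`: 5150 nM

In an ADME assay on Left cardiac atrium (Cavia porcellus) (on this read-out lower numbers stand for an effect already at smaller amounts and higher numbers for an effect only at larger amounts of compound), compound 1 gives 93 nM, the lowest of the two numbers. Compound 2 gives 5150 nM; it differs from compound 1 in more than one place, so the pair shows only the gap between its two values, beyond the scatter. Compound 3 `CCOC(=O)C1=C(C)NC(C)=C(C(=O)OCC)C1c1c(-c2cc(OC)cc(OC)c2)nc2sc(Br)cn12` carries the change (3,5-dimethoxyphenyl in place of 4-(trifluoromethoxy)phenyl on an aromatic carbon). Going by the values given here, no single-place step of this kind is known here, so the expectation rests on compound 1 alone. Compound 3 is expected to give a moderately higher number, a step of a 3.2-fold higher number from compound 1 to compound 3 (0.51 log units; beyond the scatter), with an estimate of 300 nM in a range from 80 nM to 1500 nM.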

Compound 3, half-maximal effective concentration: 25 nM
Estimate against measurement, compound 3: 12-fold (1.08 log units) above; measured number below the stated range.
By their numbers in this assay, from the lowest: compound 3; then compound 1; then compound 2.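

In this assay the swap of 4-(trifluoromethoxy)phenyl for 3,5-dimethoxyphenyl gives a 3.7-fold lower number from compound 1 to compound 3 (0.57 log units; beyond the scatter) as the only single-place step shown, so this position on the five-membered aromatic ring answers to the aryl group alone, with the rest of compound 1 held fixed. The read-out here tolerates a phenyl carrying two methoxy groups. Nothing at hand gives a reason for this step.

Open, from the compounds shown here alone, is whether an amine or a carboxylic acid on this phenyl would keep the number as low, and whether the step holds on the core without bromine.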